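The source may report more compounds than this note shows. Statements on the series, on what has been measured and on what is new or still open speak of the compounds shown alone.

Of the compounds shown here, three built on one shared core have so far been tested in a functional assay on HL-60 cells (Homo sapiens) for cytotoxicity, read by CellTiter-Blue, with a stated time of 48 h; on this read-out lower numbers stand for stronger inhibition and higher numbers for weaker inhibition. Compound 1 `CCOC(=O)CC1C(C(=O)OC)=C(N)Oc2ccc(-c3cc(OC)cc(OC)c3)cc21` gives 10800 nM, and compound 2 `CCOC(=O)CC1C(C#N)=C(N)Oc2ccc(-c3cc(OC)cc(OC)c3)cc21` gives 19600 nM. Compound 3 `CCOC(=O)CC1C(C(=O)OCC)=C(N)Oc2ccc(-c3cccc(F)c3)cc21` gives 76400 nM, the highest of the three numbers and therefore the weakest inhibition, with its gaps to both others beyond the scatter.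

The next compound, compound 4 `CCOC(=O)CC1C(C(=O)OCC)=C(N)Oc2ccc(-c3cccnc3)cc21`, keeps everything in compound 3 except one group: pyridin-3-yl in place of 3-fluorophenyl on an aromatic carbon. Pyridin-3-yl takes the place of 3-fluorophenyl on an aromatic carbon.

Going by the values given here, the only measured step that changes a single place is a 1.8-fold higher number from compound 1 to compound 2 (0.26 log units; within the scatter). It lies within the scatter, but it concerns cyano in place of methoxycarbonyl, elsewhere on the molecule, so it bears only loosely on this swap. Compound 1 and compound 2 carry a different group at the place that changes here, yet they also differ from compound 3 elsewhere, so their lower numbers cannot be assigned to that place alone. The best guide is therefore the value of compound 3, 76400 nM, and no shift beyond the scatter is expected. The estimated step is a 1.3-fold lower number from compound 3 to compound 4 (0.10 log units; within the scatter). Compound 4 is estimated at 60000 nM, with an expected range from 22000 nM to 150000 nM.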

Compound 4, half-maximal inhibitory concentration: 21500 nM
Beside the measured number, compound 4's estimate is 2.8-fold (0.45 log units) above it; measured number outside the range, below it.
By their numbers in this assay, from the lowest: compounds 1, 2 and 4 (each within the scatter of the next); then compound 3.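

In this assay, going by these compounds alone, replacing 3-fluorophenyl with pyridin-3-yl on the aromatic carbon gives a 3.6-fold lower number from compound 3 to compound 4 (0.55 log units; beyond the scatter), the first single-place change at this position and one large enough to stand beyond the scatter. Within the data shown here, the only earlier single-place step, a 1.8-fold higher number from compound 1 to compound 2 (0.26 log units; within the scatter), lay within the scatter and concerned a different place, so compound 4 gives the first sign that the number can respond to a change of structure on this series. The swap changes the ring itself, bringing in a ring nitrogen that counts as a hydrogen-bond acceptor and removing a fluorine, but no measurement shown explains why the number falls.

This one swap cannot separate the gain from adding the ring nitrogen from the effect of losing the fluorine, and a plain phenyl group at this place would be needed to tell those two apart. Going by these compounds, it also remains open whether the location of the nitrogen within the ring matters, as a comparison with pyridin-4-yl or pyridin-2-yl would show, and whether the step holds with the other groups on the shared core.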